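The compounds below may be only part of what the source reports. "The series", "measured", "known", "first", "only" and "open" are said of these compounds alone.

Compound 2 `COc1cccc(/C=N/NC(=O)CSc2nnc(-c3ccncc3)o2)c1` is the closer reference point. Going by the values given here, in a functional assay on HepG2 cells (Homo sapiens) for cytotoxicity, read by MTT assay, with a stated time of 48 h (a lower number here means a stronger inhibitor, a higher number a weaker inhibitor), compound 2 gives 9170 nM, and the only comparison available is compound 1 `Cc1ccc(/C=N/NC(=O)CSc2nnc(-c3ccncc3)o2)cc1`, which in this assay gives 10000 nM; the step of a 1.1-fold lower number from compound 1 to compound 2 (0.04 log units; within the scatter) shows the two sitting together. Compound 3 `O=C(CSc1nnc(-c2ccncc2)o1)N/N=C/c1ccccc1[N+](=O)[O-]` differs from compound 2 by 2-nitrophenyl in place of 3-methoxyphenyl on a carbon with a double bond to nitrogen. Among the compounds with values here, the single measured step at this position stayed within the scatter, so no step beyond the scatter is expected for a 1.1-fold higher number from compound 2 to compound 3 (0.04 log units; within the scatter). For compound 3 in this assay the estimate is 10000 nM, expected to fall between 4000 nM and 25000 nM.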

Compound 3, half-maximal inhibitory concentration: 24700 nM
Compound 3: middle estimate off by 2.5-fold (0.39 log units), on the low side; measured number inside the range.
By their numbers in this assay, from the lowest: compounds 2 and 1 (each within the scatter of the next); then compound 3.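

Placing 2-nitrophenyl on this carbon gives the first change beyond the scatter in this assay, seen both in (a 2.7-fold higher number from compound 2 to compound 3 (0.43 log units; beyond the scatter)) and in (a 2.5-fold higher number from compound 1 to compound 3 (0.39 log units; beyond the scatter)). The group at this position can therefore make a compound weaker, whereas the earlier swap of 4-methylphenyl for 3-methoxyphenyl showed no such change. Nothing available explains this shift. On these data alone, it remains open whether 4-nitrophenyl would give the same weakening, which would help separate the nitro group itself from where it sits on the ring. Also open, as far as these compounds go, is whether a phenyl ring carrying an amine or a carboxylic acid could bring the number down.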